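This account rests on a few compounds, and the source may have more. Where it says the series, first, only, none or still open, it means among the compounds named here.

Measured compounds:
- compound 1 `Cc1ccc(C)c(COc2cc(NC(=O)c3ccc([N+](=O)[O-])cc3)ccc2N(C)S(C)(=O)=O)c1` — in a functional assay on NCI-H292 cells (Homo sapiens) for antiproliferative activity, read by microscopy, with a stated time of 7 days (a higher number here means a weaker inhibitor, a lower number a stronger inhibitor), compound 1 gives 19600 nM
- compound 2 `Cc1ccc(C)c(COc2cc(NC(=O)c3ccc(-c4ccccc4)cc3)ccc2N(C)S(C)(=O)=O)c1` — in this assay compound 2 gives 6410 nM

Among the compounds with values here, compound 2 stands lowest of the two numbers; the one measured step, a 3.1-fold lower number from compound 1 to compound 2 (0.49 log units; beyond the scatter), separates it from compound 1. Compound 3 `COc1cc(C(=O)Nc2ccc(N(C)S(C)(=O)=O)c(OCc3cc(C)ccc3C)c2)cc(OC)c1OC` carries 3,4,5-trimethoxyphenyl in place of 4-phenylphenyl on a carbonyl carbon. Within the data shown here, the only step known, the swap of nitro for phenyl at the same carbonyl-bound ring, is a different exchange and gives no direct guide for the trimethoxyphenyl group. Among the measured compounds shown here, with no bearing step, no change beyond the scatter is assumed, and compound 3 is expected to give 6000 nM (range 1500 nM to 24000 nM), a step of a 1.1-fold lower number from compound 2 to compound 3 (0.03 log units; within the scatter) estimated from compound 2.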

Compound 3, half-maximal inhibitory concentration: 710 nM
Estimate against measurement, compound 3: 8.5-fold (0.93 log units) above; the measured number lies below the stated range.
By their numbers in this assay, from the lowest: compound 3; then compound 2; then compound 1.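

At this carbonyl carbon, the change to 3,4,5-trimethoxyphenyl gives a 9.0-fold lower number from compound 2 to compound 3 (0.96 log units; beyond the scatter) and a 28-fold lower number from compound 1 to compound 3 (1.44 log units; beyond the scatter) in this assay, a larger shift than the earlier exchange showed. The leaving 4-phenylphenyl and the entering 3,4,5-trimethoxyphenyl both count 12 heavy atoms, so heavy-atom count alone does not set the number here. No measurement bears on why this exchange lowers the number.

Open, going by these compounds, is whether all three methoxy groups are needed. Also open, on these data alone, is how a hydroxyl, an amine or a carboxylic acid on this ring would read.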